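This account rests on a few compounds, and the source may have more. Where it says the series, first, only, none or still open, it means among the compounds named here.

In a functional assay on A549 cells (Homo sapiens) for cytotoxicity, read by MTT assay, with a stated time of 72 h (on this read-out higher numbers stand for weaker inhibition and lower numbers for stronger inhibition), compound 1 `COc1cc2c(Oc3ccc(NC(=O)c4cc(-c5ccccc5)ccn4)cc3F)ccnc2cc1OCCCN1CCN(C)CC1` gives 340 nM. Among the measured compounds shown here, that is the only number in view: compound 2 `COc1ccc(-c2ccnc(C(=O)Nc3ccc(Oc4ccnc5cc(OCCCN6CCN(C)CC6)c(OC)cc45)c(F)c3)c2)cc1`, a close relative on the same core, is recorded in this assay as "not determined" (no result reported), so compound 1 stands alone, with no second measured value to set it against and no measured step of any kind to draw on.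

Compound 3 `COc1cc2c(Oc3ccc(NC(=O)c4cc(-c5ccccc5)ccn4)cc3F)ccnc2cc1OCCCN1CCCC1` differs from compound 1 in a single place: pyrrolidin-1-yl in place of 4-methylpiperazin-1-yl on a saturated chain carbon, three bonds along the chain from an oxygen on an aromatic ring. The amide, the fluorinated ring and the rest of the shared core are kept as they stand in compound 1.

For the measured compounds named here, with no measured pair of this kind to lean on, the step is expected to be small and without a clear direction, staying within the ordinary scatter of this assay, giving a 1.0-fold higher number from compound 1 to compound 3 (0.01 log units; within the scatter). Compound 3 is therefore expected to give about 350 nM in this assay, with a plausible range from 120 nM to 1000 nM.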

Compound 3, half-maximal inhibitory concentration: 1580 nM
Estimate against measurement, compound 3: 4.5-fold (0.65 log units) below; the measured number lies above the stated range.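

In this assay, among the compounds shown here, the step from 4-methylpiperazin-1-yl to pyrrolidin-1-yl gives a 4.6-fold higher number from compound 1 to compound 3 (0.67 log units; beyond the scatter), the first measured change, and it shows that the group on this saturated chain carbon, three bonds along the chain from an oxygen on an aromatic ring, is not indifferent to the read-out. Here the smaller pyrrolidin-1-yl ring, with one hetero atom where 4-methylpiperazin-1-yl has two, goes with weaker inhibition, although this rests on a single pair on one core. Nothing available accounts for the size or direction of this step.

The compounds shown leave open how other groups at this place, such as morpholin-4-yl, piperidin-1-yl or dimethylamino, would compare. They also leave open whether the step would hold on a shorter or longer chain than 3-(4-methylpiperazin-1-yl)propyl.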